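The source may report more compounds than this note shows. Statements on the series, on what has been measured and on what is new or still open speak of the compounds shown alone.

Measured in an ADME assay on BHK cells (Mesocricetus auratus) for cytotoxicity, read by MTT assay, with a stated time of 96 h; on this read-out higher numbers stand for lower toxicity in this test and lower numbers for higher toxicity in this test:
- Compound 1 `CC[C@H]1CC[C@H](c2ccc(NC(=S)Nc3cccc(C(F)(F)F)c3)cc2)CC1` gives 10000 nM
- Compound 2 `O=[N+]([O-])c1ccc(NC(=S)Nc2cccc(C(F)(F)F)c2)cc1` gives 9500 nM
- Compound 3 `FC(F)(F)c1cccc(NC(=S)Nc2ccccc2)c1` gives 41000 nM

Compound 3 stands highest of these three at 41000 nM on this read-out. Compound 4 `Fc1ccccc1NC(=S)Nc1cccc(C(F)(F)F)c1` has fluoro in place of hydrogen on an aromatic carbon, ortho to a large group (fluoro in place of hydrogen on an aromatic carbon). Among the measured compounds shown here, two measured steps bear on this: a 4.3-fold higher number from compound 2 to compound 3 (0.64 log units; beyond the scatter) and a 4.1-fold higher number from compound 1 to compound 3 (0.61 log units; beyond the scatter) are both modest. In each, a group on the aromatic ring gives way to hydrogen and the number rises. Neither step involves fluoro, so they guide only loosely. A small downward change is therefore expected in this assay, probably within the scatter, with a 1.4-fold lower number from compound 3 to compound 4 (0.14 log units; within the scatter) as the expected step. Compound 4 is estimated at 30000 nM with an expected range from 12000 nM to 60000 nM in this test.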

Compound 4, half-maximal cytotoxic concentration: 54000 nM
For compound 4 the middle estimate is 1.8-fold (0.26 log units) below the measured one; the range from low to high includes it.
By their numbers in this assay, from the lowest: compounds 2 and 1 (each within the scatter of the next); then compounds 3 and 4 (each within the scatter of the next).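

In this assay, fluoro in place of hydrogen on an aromatic carbon, ortho to a large group, gives a 1.3-fold higher number from compound 3 to compound 4 (0.12 log units; within the scatter), so the numbers for these two compounds cannot be told apart. A substituent on this ring therefore need not go with a lower number, although nitro in compound 2 and 4-ethylcyclohexyl in compound 1 do. Nothing measured here gives a reason for this result. Going by these compounds, whether an amine or a methoxy group at this same place would also stay close to compound 3 remains open, as does the effect of fluoro elsewhere on the ring.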